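The compounds below may be only part of what the source reports. "The series", "measured", "known", "first", "only" and "open" are said of these compounds alone.

The measured compounds, all tested in a functional assay on a cell-free system (plasma, Oryctolagus cuniculus) for inhibition, with stated times of 5 min, 1 min and 6 min; a lower number here means a stronger inhibitor, a higher number a weaker inhibitor:

compound 1 `CCOC(=O)c1c(C)nc(-c2cccc(C#N)c2)n1OC` gives 9130 nM
compound 2 `CCOC(=O)c1c(C)nc(-c2cccc(C#N)c2)n1C(C)C` gives 9260 nM
compound 3 `CCOC(=O)c1c(C)nc(-c2cccc(C#N)c2)n1OCCCO` gives 11400 nM

Compound 1 has the lowest of the three numbers, but its nearest neighbour, compound 2, differs by a 1.0-fold higher number from compound 1 to compound 2 (0.01 log units; within the scatter), and the furthest, compound 3, by a 1.2-fold higher number from compound 1 to compound 3 (0.10 log units; within the scatter); neither gap is more than the scatter of repeated measurements, so the three compounds cannot be told apart on these numbers.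

Compound 4 `CCOC(=O)c1c(C)nc(-c2cccc(C#N)c2)n1OCc1ccc(F)cc1` is not yet measured. It differs from compound 1 in one place: 4-fluorophenyl in place of hydrogen on a saturated chain carbon bound to an oxygen on an aromatic ring. Cut one bond further out, the same difference reads methoxy to (4-fluorobenzyl)oxy.

Among the measured compounds shown here, two measured steps touch the same part of the shared core. The step from compound 1 to compound 3 extends the chain on the oxygen bound to the aromatic nitrogen and gives a 1.2-fold higher number from compound 1 to compound 3 (0.10 log units; within the scatter). The step from compound 1 to compound 2 replaces the whole methoxy group on that nitrogen and gives a 1.0-fold higher number from compound 1 to compound 2 (0.01 log units; within the scatter). Both stay within the scatter, so this position tolerated the changes tried so far without any shift in this assay. For the measured compounds named here, a 4-fluorophenyl is larger than anything yet placed there, and no measured step tests a group of that kind, so the expectation rests on the two flat steps alone: no step beyond the scatter, in either direction, with some added uncertainty.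

Compound 4 is therefore expected to give about 8500 nM, somewhere between 3000 nM and 25000 nM, which means an estimated step of a 1.1-fold lower number from compound 1 to compound 4 (0.03 log units; within the scatter).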

Compound 4, half-maximal inhibitory concentration: 5880 nM
For compound 4 the middle estimate is 1.4-fold (0.16 log units) above the measured one, within the range that was stated.
By their numbers in this assay, from the lowest: compounds 4, 1, 2 and 3 (each within the scatter of the next).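

In this assay, a ring can sit on the saturated chain carbon bound to an oxygen on an aromatic ring without the number leaving the scatter (a 1.6-fold lower number from compound 1 to compound 4 (0.19 log units; within the scatter)). Among the compounds shown here, no earlier compound carried a ring there, so none could show this. The same holds against the two other groups: (4-fluorobenzyl)oxy in place of isopropyl on the aromatic nitrogen gives a step within the scatter (a 1.6-fold lower number from compound 2 to compound 4 (0.20 log units; within the scatter)), and so does 4-fluorophenyl in place of 2-hydroxyethyl (a 1.9-fold lower number from compound 3 to compound 4 (0.29 log units; within the scatter)), which leaves all four compounds impossible to tell apart on these numbers, even with 4-fluorophenyl bringing far more heavy atoms than the hydrogen it replaces. No separate measurement is available that bears on this result and could help interpret it.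

As far as these compounds go, whether any group at this place can move the number beyond the scatter remains open, and so does the part played by the fluorine on the new ring. An unsubstituted benzyl, or an amine or a carboxylic acid at the end of a longer chain, would put both questions to this position directly.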